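Pyridin-4-yl in place of 4-aminophenyl

The compounds below may be only part of what the source reports. "The series", "measured", "known", "first", "only" and "open" are said of these compounds alone.

In a functional assay on MDA-MB-231 cells (Homo sapiens) for inhibition, read by MTT assay, with a stated time of 72 h (a lower number here means a stronger inhibitor, a higher number a weaker inhibitor), compound 3 (`CC(C)(C)n1cc2c(n1)C(=O)CC1(CCN(C(=O)c3cc(-c4ccc(N)cc4)nc4ccccc34)CC1)O2`) gives 4960 nM, within the scatter of compound 2 (`COc1ccc(-c2cc(C(=O)N3CCC4(CC3)CC(=O)c3nn(C(C)(C)C)cc3O4)c3ccccc3n2)cc1OC`) at 7130 nM. Compound 1 (`CC(C)(C)n1cc2c(n1)C(=O)CC1(CCN(C(=O)c3cc(-c4ccccc4)nc4ccccc34)CC1)O2`), which carries a phenyl group, returns only a limit, > 10000 nM. The steps away from compound 1 are therefore floors, not exact sizes: an at least 1.4-fold lower number from compound 1 to compound 2 (0.14 log units; that floor lies within the scatter), and an at least 2.0-fold lower number from compound 1 to compound 3 (0.30 log units; that floor lies within the scatter).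

Compound 4 (`CC(C)(C)n1cc2c(n1)C(=O)CC1(CCN(C(=O)c3cc(-c4ccncc4)nc4ccccc34)CC1)O2`) differs from compound 3 on an aromatic carbon next to the ring nitrogen: pyridin-4-yl in place of 4-aminophenyl on an aromatic carbon. Among the measured compounds shown here, no measured step introduces this pyridine ring, so the guidance is indirect. For the measured compounds named here, the closest precedent is the exchange of one aryl group for another, which gave a 1.4-fold lower number from compound 2 to compound 3 (0.16 log units; within the scatter). That small step suggests little movement, although compound 4 loses the amino group of compound 3 and could drift towards the limit of compound 1. The expected change is a 1.6-fold higher number from compound 3 to compound 4 (0.21 log units; within the scatter), which would not clearly exceed the scatter. For compound 4 the estimate is 8000 nM, with an expected range from 3000 nM to 20000 nM.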

Compound 4, half-maximal inhibitory concentration: 1650 nM
The estimate for compound 4 lay 4.8-fold (0.69 log units) above the measured number, outside the stated range (below it).
By their numbers in this assay, from the lowest: compound 4; then compounds 3 and 2 (each within the scatter of the next). At a limit, above all of these: compound 1.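

Among the aryl groups on this aromatic carbon next to the ring nitrogen, pyridin-4-yl gives the first change that is clearly beyond the scatter in this assay: a 3.0-fold lower number from compound 3 to compound 4 (0.48 log units; beyond the scatter), and a 4.3-fold lower number from compound 2 to compound 4 (0.64 log units; beyond the scatter). Against the phenyl group of compound 1, the entering ring swaps one ring carbon for nitrogen, giving an at least 6.0-fold lower number from compound 1 to compound 4 (0.78 log units; beyond the scatter), so a lower number at this position does not require the amino group of compound 3 or the methoxy groups of compound 2. The number for compound 1 is a limit, so this last step is a floor and not an exact size: the limit of > 10000 nM in this assay, at which 1 of the 4 values shown sits.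

From the compounds shown here alone, whether the place of the ring nitrogen matters remains open, as a pyridin-3-yl or pyridin-2-yl group would be needed to test it. The numbers also leave open why the pyridin-4-yl group lowers the number in these cells.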